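A few compounds are considered here, and "the series" means these few. Any claim that something is new, unique, unknown or untested is made for them only; others in the source may bear on it.

Measured compounds:
- compound 1, `CCCCN(CCCC)Cc1cn(CC(O)COC(=O)NCc2ccccc2)nn1`: 42% in an assay on nucleic acid for inhibition of Nucleic Acid, read by fluorescence, tested at 100 uM; on this read-out lower numbers stand for less inhibition and higher numbers for more inhibition at the one concentration tested (going by the name of the read-out)
- compound 2, `CN(Cc1cn(CC(O)COC(=O)NCc2ccccc2)nn1)CC1CCCCC1`: 32%
- compound 3, `CN(CCCc1ccccc1)Cc1cn(CC(O)COC(=O)NCc2ccccc2)nn1`: 79%

Compound 2 sits lowest of the three numbers. Its nearest neighbour is compound 1, a number 10 percentage points lower from compound 1 to compound 2 (within the scatter), so the two are not separable. The step to compound 3 is another matter: a number 47 percentage points higher from compound 2 to compound 3 (beyond the scatter), a clear change that comes from the amine side of the shared core.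

Compound 4, `CCCCNC(=O)OCC(O)Cn1cc(CN(C)CC2CCCCC2)nn1`, keeps the amine side of compound 2 untouched and alters the carbamate end instead: propyl in place of phenyl on a saturated chain carbon bound to an amide-type nitrogen. Neither measured step touches this part of the molecule. The steps from compound 1 to compound 2 and from compound 2 to compound 3 both lie on the saturated chain carbon bound to the amine nitrogen, so nothing in the data speaks to the carbamate end. Within the data shown here, with no comparable step to lean on, the expectation is a change of no more than the scatter; the step expected is no change at the digits printed from compound 2 to compound 4 (within the scatter). Compound 4 is therefore estimated at 32%, with a range from 14% to 52%.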

Compound 4, a percentage reported as inhibition, at one concentration (the size of the read-out at that concentration, not a potency): 12%
Compound 4: middle estimate off by 20 percentage points, on the high side, outside the stated range (below it).
By their numbers in this assay, from the lowest: compound 4; then compounds 2 and 1 (each within the scatter of the next); then compound 3.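

The carbamate end is not silent in this assay: with the amine side held as in compound 2, propyl in place of phenyl on a saturated chain carbon bound to an amide-type nitrogen gives a number 20 percentage points lower from compound 2 to compound 4 (beyond the scatter) and is the only step shown at this position. The read-out therefore responds to this end of the molecule as well as to the amine side, and here the loss of the six-membered aromatic ring goes with a lower number, though this rests on a single pair. No measurement at hand accounts for this step.

Going by these compounds, it remains open whether the aromatic ring or the chain length governs the step, which a pyridyl ring or a hexyl chain at this position would help to separate. On these data alone, it is also open whether the same change gives a similar step with the amine side of compound 1 or compound 3.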